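Hydrogen in Place of Bromo on a Quiet Phenyl Group

The source may report more compounds than this note shows. Statements on the series, on what has been measured and on what is new or still open speak of the compounds shown alone.

In a functional assay on OVCAR-5 cells (Homo sapiens) for inhibition, read by CCK-8 assay, with a stated time of 72 h, tested at 1 uM (on this read-out higher numbers stand for more inhibition of growth at the one concentration tested and lower numbers for less inhibition of growth), compound 2 `CN(C)C(=O)c1cc2cnc(Nc3ccc(NC(=O)C4(C(=O)Nc5cccc(Br)c5)CC4)cc3)nc2n1C1CCCC1` gives 0.04% and compound 1 `CN(C)C(=O)c1cc2cnc(Nc3ccc(NC(=O)C4(C(=O)Nc5ccc(Cl)c(C(F)(F)F)c5)CC4)cc3)nc2n1C1CCCC1` gives -2.4%, so the two lie within the scatter of each other. Compound 3 `CN(C)C(=O)c1cc2cnc(Nc3ccc(NC(=O)C4(C(=O)Nc5ccccc5)CC4)cc3)nc2n1C1CCCC1` carries hydrogen in place of bromo on an aromatic carbon, (hydrogen in place of bromo on an aromatic carbon). For the measured compounds named here, the one measured step that bears on this change, a number 2.4 percentage points higher from compound 1 to compound 2 (within the scatter), alters the same phenyl group and stays within the scatter. In this assay the expected step, a number 2 percentage points higher from compound 2 to compound 3 (within the scatter), therefore also stays within the scatter. The estimate for compound 3 is 2%, with an expected range of -8% to 14%.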

Compound 3, percent growth inhibition at one concentration: 52.1%
The estimate for compound 3 lay 50.1 percentage points below the measured number; the whole stated range lies below it.
By their numbers in this assay, from the lowest: compounds 1 and 2 (each within the scatter of the next); then compound 3.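

In this assay the step of a number 52.1 percentage points higher from compound 2 to compound 3 (beyond the scatter) comes with the loss of bromo alone, and the step of a number 54.5 percentage points higher from compound 1 to compound 3 (beyond the scatter) comes with the loss of both chloro and trifluoromethyl. The substitution on this phenyl group therefore matters, which compounds 1 and 2, within the scatter of each other, could not show: both substituted phenyl groups lie far under the bare phenyl of compound 3. Nothing shown here gives a reason for this. Going by these compounds, whether fluoro or methyl on the same aromatic carbon would keep the inhibition of compound 3 or lose it stays open. So does whether a single substituent elsewhere on this phenyl group would do the same as bromo.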